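The compounds below may be only part of what the source reports. "The series", "measured", "known", "first", "only" and "open" are said of these compounds alone.

Measured so far in a functional assay on MV cells (Homo sapiens) for inhibition, read by sulforhodamine B assay; a higher number here means a weaker inhibitor, a lower number a stronger inhibitor:
compound 1, `C#CC(=O)N1C(CCCC)SC[C@@H]1C(=O)OCC` — 400 nM
compound 2, `C#CC(=O)N1C(c2ccccc2)SC[C@@H]1C(=O)OCC` — 400 nM
compound 3, `C#CC(=O)N1C(CCCCC)SC[C@@H]1C(=O)OCC` — 2000 nM

Compound 3 gives the highest number of the three: a 5.0-fold higher number from compound 1 to compound 3 (0.70 log units; beyond the scatter) and a 5.0-fold higher number from compound 2 to compound 3 (0.70 log units; beyond the scatter), both beyond the scatter, so compound 3 is the weakest inhibitor of the measured set. Compound 4, `C#CC(=O)N1C(c2ccc(F)cc2)SC[C@@H]1C(=O)OCC`, has not yet been measured. The change from compound 3 to compound 4 is 4-fluorophenyl in place of pentyl on a saturated ring carbon.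

For the measured compounds named here, two measured steps bear on this change. The step of a 5.0-fold higher number from compound 2 to compound 3 (0.70 log units; beyond the scatter) is the same exchange run in the opposite direction, chain for aromatic ring, and it was a modest step. The step of no change at the digits printed from compound 1 to compound 2 (within the scatter) shows that a phenyl and a butyl on that ring carbon give the same number within the scatter. Going by the values given here, the fluorine on the aromatic ring has no measured counterpart, so its contribution is unknown.

Going back from pentyl to an aromatic ring is therefore expected to bring the number down to about that of compound 2. The step to compound 4 is estimated as a 5.0-fold lower number from compound 3 to compound 4 (0.70 log units; beyond the scatter). Compound 4 is expected to give about 400 nM, with a range from 150 nM to 1200 nM.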

Compound 4, half-maximal inhibitory concentration: 400 nM
Compound 4: middle estimate and measured number agree at the digits printed; the measured number falls inside the stated range.
By their numbers in this assay, from the lowest: compounds 1, 2 and 4 (each within the scatter of the next); then compound 3.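

In this assay, for the compounds shown here, fluoro in place of hydrogen on an aromatic carbon gives no change at the digits printed from compound 2 to compound 4 (within the scatter) and so settles the one part of this change that had no measured counterpart, with 4-fluorophenyl reading the same as phenyl on this saturated ring carbon. The exchange of pentyl for 4-fluorophenyl gives a 5.0-fold lower number from compound 3 to compound 4 (0.70 log units; beyond the scatter) and the exchange of butyl for 4-fluorophenyl gives no change at the digits printed from compound 1 to compound 4 (within the scatter) as a second comparison, so at this position butyl and both aromatic groups now form one group of three, and the pentyl of compound 3 alone stands apart from all of them. Nothing at hand accounts for why pentyl alone stands apart from the other three groups.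

Still open, as far as these compounds go, is whether a longer chain such as hexyl follows pentyl or returns to the level of butyl, and whether a chain shorter than butyl, such as ethyl, belongs with the group of three. Also open, from the compounds shown here alone, is whether an aromatic ring bearing an amine or a methoxy group in place of the fluorine would still read with phenyl, and what a carboxylic acid in place of the ethoxycarbonyl group would do on the core of compound 4.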